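Shifting One Methoxy Group on a Shared Core

The source may report more compounds than this note shows. Statements on the series, on what has been measured and on what is new or still open speak of the compounds shown alone.

Compound 1 `COc1ccccc1/C=C/C(=O)OC/C=C/c1cc(OC)c(OC)cc1OC` was tested in a functional assay on the whole organism (strain Kunming) with Mus musculus as the target, with a stated time of 0.5 h, at a dose of 300 mg/kg by the intraperitoneal route (on this read-out lower numbers stand for a stronger effect and higher numbers for a weaker effect at the one dose given), where compound 1 gives 50%. Two measured compounds differ from it in a single place. Compound 2 `COc1cc(OC)c(OC)cc1/C=C/COC(=O)/C=C/c1ccc(F)cc1` gives 0%, and the step of a number 50 percentage points lower from compound 1 to compound 2 (beyond the scatter) is large. Compound 3 `COc1cccc(/C=C/C(=O)OC/C=C/c2cc(OC)c(OC)cc2OC)c1` gives 50%, so no change at the digits printed from compound 1 to compound 3 (within the scatter). On these three numbers compound 1 stands level with compound 3, together the highest of the three, with compound 2 far below them.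

Compound 4 `COc1ccc(/C=C/C(=O)OC/C=C/c2cc(OC)c(OC)cc2OC)cc1` has not yet been measured. It differs from compound 1 in one place: 4-methoxyphenyl in place of 2-methoxyphenyl on a double-bonded chain carbon bound to a double-bonded chain carbon. Of the measured steps, the change to compound 3 is the closer guide, as it also swaps one methoxyphenyl for another methoxyphenyl in the same place and left the number unchanged. The change to compound 2 shows that a different group in that place can remove the effect entirely, so some room for a drop remains. The expected step of a number 10 percentage points lower from compound 1 to compound 4 (within the scatter) is therefore small. Compound 4 is estimated at 40%, within 0% to 70%.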

Compound 4, a percentage reported as activity, at one dose (the size of the read-out at that dose, not a potency): 0%
For compound 4 the middle estimate is 40 percentage points above the measured one; measured number inside the range.
By their numbers in this assay, from the lowest: compounds 2 and 4 (each within the scatter of the next); then compounds 1 and 3 (each within the scatter of the next).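

In this assay the place of the methoxy group on this phenyl ring turns out to matter: 4-methoxyphenyl in place of 2-methoxyphenyl gives a number 50 percentage points lower from compound 1 to compound 4 (beyond the scatter) and 4-methoxyphenyl in place of 3-methoxyphenyl gives a number 50 percentage points lower from compound 3 to compound 4 (beyond the scatter) even though the earlier swap between the other two methoxyphenyl groups changed nothing. So carrying a methoxy group does not by itself set the number among these compounds. Methoxy in place of fluoro on an aromatic carbon gives no change at the digits printed from compound 2 to compound 4 (within the scatter) and so the 4-methoxyphenyl and 4-fluorophenyl compounds stand together at the low end, apart from compounds 1 and 3.

Nothing available here explains why these groups separate in this way. On these data alone, it also stays open whether an amine or a carboxylic acid in place of the methoxy of the 4-methoxyphenyl group would keep the number as low.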